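A Hydroxyethyl Chain Replaces Phenyl on the Shared Core

A few compounds are considered here, and "the series" means these few. Any claim that something is new, unique, unknown or untested is made for them only; others in the source may bear on it.

Three pyrazolopyridine-free descriptions aside, the shared core carries a phenyl on its pyrazole nitrogen in every compound here. Compound 1 `c1ccc(-n2cc3cnc(-c4ccsc4)cc3n2)cc1` bears a thiophen-3-yl on the six-membered ring and in a functional assay on MCF7 cells (Homo sapiens) for inhibition, read by fluorescence, with a stated time of 72 h (on this read-out lower numbers stand for stronger inhibition of growth and higher numbers for weaker inhibition of growth), compound 1 gives 9800 nM. Compound 2 `c1ccc(-c2cc3nn(-c4ccccc4)cc3cn2)cc1` carries phenyl at that position and in this assay compound 2 gives 4800 nM, the lowest of the three numbers. Compound 3 `Cc1nc(-c2ccccc2)cc2nn(-c3ccccc3)cc12` adds a methyl and in this assay compound 3 gives 11000 nM. The two steps among them are modest: a 2.0-fold lower number from compound 1 to compound 2 (0.31 log units; beyond the scatter) and a 2.3-fold higher number from compound 2 to compound 3 (0.36 log units; beyond the scatter).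

Compound 4 `OCCc1cc2nn(-c3ccccc3)cc2cn1` differs from compound 2 in one place: 2-hydroxyethyl in place of phenyl on an aromatic carbon. Neither measured step swaps an aromatic ring for an open chain bearing a hydrogen-bond donor, so neither bears directly on it; both show that small changes at this end of the core move the number only modestly. The account therefore expects a modest step upward, a 2.5-fold higher number from compound 2 to compound 4 (0.40 log units; beyond the scatter), giving compound 4 an estimated 12000 nM with a range from 4000 nM to 40000 nM.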

Compound 4, concentration for 50% growth inhibition: > 100000 nM
Compound 4 ended at the assay's limit; the forecaster's own chance of this, stated with the estimate: 15%; middle value at least 8.3-fold (0.92 log units) from the limit.
By their numbers in this assay, from the lowest: compound 2; then compounds 1 and 3 (each within the scatter of the next). At a limit, above all of these: compound 4.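

In this assay the reading for compound 4 is a limit and not a number: the limit of > 100000 nM in this assay, at which 1 of the 4 values shown sits. At this aromatic carbon next to the ring nitrogen, compounds 1 and 2 both give measurable numbers with a ring in place, whereas exchanging either ring for the open 2-hydroxyethyl chain gives an at least 20-fold higher number from compound 2 to compound 4 (1.31 log units; beyond the scatter) and an at least 10-fold higher number from compound 1 to compound 4 (1.00 log units; beyond the scatter). Within the data shown here, the position therefore responds far more to losing the aromatic ring than to the choice between thiophen-3-yl and phenyl, a contrast the earlier steps could not show.

The change removes the ring and adds the hydroxyl together, so the compounds shown cannot tell which of the two carries the step. A plain ethyl chain, a cyclohexyl ring or a 2-aminoethyl chain at this carbon would bear on that question.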